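The source may hold more compounds than are shown below. What is called first, only, known or untested is meant among the compounds shown, and "the series" means these compounds.

Working notes on a small sulfonamide series. Compound 1 `O=S(=O)(Nc1ccc2oc(-c3ccccc3)nc2c1)c1cccc(C(F)(F)F)c1`, compound 2 `O=S(=O)(Nc1ccc2oc(-c3ccccc3)nc2c1)c1ccc(O)cc1` and compound 3 `CS(=O)(=O)Nc1ccc(-c2nc3ccccc3o2)cc1` share one core; compound 4 `Cc1ccc(S(=O)(=O)Nc2ccc3oc(-c4ccccc4)nc3c2)cc1` has not yet been run. In an ADME assay on HEK293 cells (Homo sapiens) for cytotoxicity, read by resazurin assay, with a stated time of 48 h (on this read-out higher numbers stand for lower toxicity in this test and lower numbers for higher toxicity in this test), compound 1 gives > 100000 nM, which is a limit of the assay and not a number. In this assay compound 2 gives > 100000 nM, again only a limit. In this assay compound 3 gives > 100000 nM, also a limit. Compound 2 therefore stands where every measured value of the series stands, at the limit of > 100000 nM in this assay, at which 3 of the 3 values shown sit, and no ordering among the three measured compounds can be read from these results. Going by the values given here, no step between measured compounds can be computed here, since no pair of them returned two numbers.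

The change from compound 2 to compound 4 is methyl in place of hydroxy on an aromatic carbon. Because all three measured results sit at the limit of > 100000 nM in this assay, at which 3 of the 3 values shown sit, the expected step of a number no higher from compound 2 to compound 4 (the limit leaves the size open) is none beyond the scatter, with the assay most likely returning a limit once more. Compound 4 is thus estimated at about 100000 nM in this assay, with a range of 40000 nM to 300000 nM, and the chance that only a limit is reported is judged high.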

Compound 4, half-maximal cytotoxic concentration: 75000 nM
Compound 4: the middle estimate sits 1.3-fold (0.12 log units) above what was measured; measured number inside the range.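

In this assay compound 4 gives 75000 nM, the first result in the series that is a number. The other results shown are all limits: the limit of > 100000 nM in this assay, at which 3 of the 4 values shown sit.

Compound 2 gives > 100000 nM, which is a limit of the assay and not a number. Exchanging the hydroxy for methyl on this aromatic carbon, para to a large group, therefore gives an at least 1.3-fold lower number from compound 2 to compound 4 (0.12 log units; that floor lies within the scatter), so the change from 4-hydroxyphenyl to 4-methylphenyl has only a lower bound on its size, and that bound does not by itself show a real difference in the read-out.

The compounds shown leave open how far the true value of compound 2 lies from that of compound 4, and so whether the hydroxy to methyl change matters at all in this test. They also leave open what an amine, a carboxylic acid or a longer chain such as propyl would return at the same position on the ring, and whether any of these would give a number or a limit.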